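Adding a Second Chloro to the Core of Compound 3

The compounds below may be only part of what the source reports. "The series", "measured", "known", "first", "only" and "open" are said of these compounds alone.

Compound 1, `Cc1ccccc1-c1cc(C#Cc2ccc(CCC(=O)O)cc2)ccn1`, gives 1070 nM in an in vitro functional assay on 1321-N1 cells for agonist activity at Free fatty acid receptor 1 (Homo sapiens), read by fluorescence, spectrophotometry and calcium flux; on this read-out higher numbers stand for an effect only at larger amounts of compound and lower numbers for an effect already at smaller amounts.
Compound 2, `O=C(O)CCc1ccc(C#Cc2ccnc(-c3ccccc3)c2)cc1`, gives 186 nM in this assay.
Compound 3, `O=C(O)CCc1ccc(C#Cc2ccnc(Cl)c2)cc1`, gives 295 nM in this assay.

Compound 3 holds the second highest of the three numbers in this assay; its nearest neighbour is reached through a 1.6-fold higher number from compound 2 to compound 3 (0.20 log units; within the scatter), its furthest through a 3.6-fold lower number from compound 1 to compound 3 (0.56 log units; beyond the scatter).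

Compound 4, `O=C(O)CCc1ccc(C#Cc2cc(Cl)nc(Cl)c2)cc1`, differs from compound 3 by chloro in place of hydrogen on an aromatic carbon of a six-membered aromatic ring with one nitrogen, next to the ring nitrogen, meta to a chloro group and meta to a large group. Within the data shown here, no measured step puts chloro in place of hydrogen. The steps that come closest are a 1.6-fold higher number from compound 2 to compound 3 (0.20 log units; within the scatter) and a 3.6-fold lower number from compound 1 to compound 3 (0.56 log units; beyond the scatter), each placing chloro where a ring had stood. Compound 4 is therefore expected to show a 1.0-fold higher number from compound 3 to compound 4 (0.01 log units; within the scatter), nothing beyond the scatter. Compound 4 is estimated at 300 nM, between 120 nM and 750 nM.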

Compound 4, half-maximal effective concentration: 40.7 nM
For compound 4 the middle estimate is 7.4-fold (0.87 log units) above the measured one; measured number below the stated range.
By their numbers in this assay, from the lowest: compound 4; then compounds 2 and 3 (each within the scatter of the next); then compound 1.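

Putting chloro in place of hydrogen on this aromatic carbon, next to the ring nitrogen, gave a 7.2-fold lower number from compound 3 to compound 4 (0.86 log units; beyond the scatter) in this assay and showed that this position, which holds hydrogen in compounds 1, 2 and 3, can move the number beyond the scatter. The earlier steps shown here had only exchanged a ring for chloro at another place on the core. No measurement shown accounts for the size of this step. From the compounds shown here alone, it stays open whether this result is specific to chloro or would also hold for a methyl, a fluoro or an amine on this carbon. Going by these compounds, it also stays open whether the step would hold with phenyl in place of the other chloro group.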